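From Sulfonyl to Carbonyl on the Ring Nitrogen

The compounds below may be only part of what the source reports. "The series", "measured", "known", "first", "only" and "open" are said of these compounds alone.

Of the compounds shown here, three sharing one core have been measured in an ADME assay on HEK293 cells (Homo sapiens) for cytotoxicity, read by MTT assay, with a stated time of 48 h (a lower number here means a stronger inhibitor, a higher number a weaker inhibitor), and their numbers sit close together. Compound 1 `COc1ccc(-c2cn3cc(C4=CCN(C(=O)C(C)(C)C)CC4)ccc3n2)cc1OC` gives 66600 nM with (tert-butyl)carbonyl on an amine nitrogen in a ring, compound 2 `COc1ccc(-c2cn3cc(C4=CCN(S(=O)(=O)C5CCCC5)CC4)ccc3n2)cc1OC` gives 103000 nM with cyclopentylsulfonyl there, and compound 3 `COc1ccc(-c2cn3cc(C4=CCN(S(=O)(=O)c5ccccc5)CC4)ccc3n2)cc1OC` gives 65600 nM with phenylsulfonyl. Compound 3 thus stands level with the other two, as every gap among the three lies within the scatter.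

Compound 4 `COc1ccc(-c2cn3cc(C4=CCN(C(=O)c5cccc(C(F)(F)F)c5)CC4)ccc3n2)cc1OC` is still unmeasured. It carries (3-(trifluoromethyl)phenyl)carbonyl in place of phenylsulfonyl on an amine nitrogen in a ring. Going by the values given here, three measured steps bear on this change. Exchanging the group on that nitrogen gave a 1.0-fold lower number from compound 1 to compound 3 (0.01 log units; within the scatter) and also a 1.5-fold higher number from compound 1 to compound 2 (0.19 log units; within the scatter) while exchanging the group on the sulfonyl sulfur gave a 1.6-fold lower number from compound 2 to compound 3 (0.20 log units; within the scatter) and so all three steps are small. Among the compounds with values here, no measured compound carries a trifluoromethyl group, so that part of the change is untested. Within the data shown here, with these steps as the only guide, no step beyond the scatter is expected in this assay for compound 4. The expected step is a 1.1-fold lower number from compound 3 to compound 4 (0.04 log units; within the scatter) as an estimate only. For compound 4 the estimated value is 60000 nM with 25000 nM to 120000 nM as the expected range.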

Compound 4, half-maximal inhibitory concentration: 68400 nM
Compound 4: the middle estimate sits 1.1-fold (0.06 log units) below what was measured; low and high end bracket the measured number.
By their numbers in this assay, from the lowest: compounds 3, 1, 4 and 2 (each within the scatter of the next).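

In this assay, (3-(trifluoromethyl)phenyl)carbonyl in place of phenylsulfonyl on the amine nitrogen in the ring gave a 1.0-fold higher number from compound 3 to compound 4 (0.02 log units; within the scatter), so this exchange alters both the linking group and the aromatic ring without a step beyond the scatter. Going by these compounds alone, the same group in place of cyclopentylsulfonyl gave a 1.5-fold lower number from compound 2 to compound 4 (0.18 log units; within the scatter), and 3-(trifluoromethyl)phenyl in place of tert-butyl on the carbonyl carbon gave a 1.0-fold higher number from compound 1 to compound 4 (0.01 log units; within the scatter), which extends the flat picture at this position to a carbonyl bearing an aromatic ring and to the first trifluoromethyl group in the set. Nothing available explains why these exchanges leave the number within the scatter.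

The separate share of the trifluoromethyl group remains open, as the compounds shown do not pair it with a plain phenyl on the carbonyl carbon. Going by these compounds, all four compounds carry a carbonyl or sulfonyl group on this nitrogen, so it also remains open how a free ring amine, a simple methyl on the nitrogen or a carboxylic acid on the phenyl ring would read.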